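The source may report more compounds than this note shows. Statements on the series, on what has been measured and on what is new or still open speak of the compounds shown alone.

Measured so far:
compound 1, `COc1ccc(-c2cc(C(=O)Nc3ccc(Oc4ccnc5cc(OCCCN6CCCCC6)c(OC)cc45)c(F)c3)c3ccccc3n2)cc1` — 290 nM
compound 2, `COc1cc2c(Oc3ccc(NC(=O)c4cc(-c5ccc(F)cc5)nc5ccccc45)cc3F)ccnc2cc1OCCCN1CCCCC1` — 21 nM
compound 3, `COc1cc2c(Oc3ccc(NC(=O)c4cc(-c5cccc(Cl)c5)nc5ccccc45)cc3F)ccnc2cc1OCCCN1CCCCC1` — 11 nM

These three compounds share one core and differ only in the aryl group attached to it. In a functional assay on NCI-H460 cells (Homo sapiens) for cytotoxicity, read by MTT assay, with a stated time of 72 h (on this read-out higher numbers stand for weaker inhibition and lower numbers for stronger inhibition), compound 3 gives the lowest of the three numbers; its gap to compound 1 is large, a 26-fold lower number from compound 1 to compound 3 (1.42 log units; beyond the scatter), whereas its gap to compound 2 is small, a 1.9-fold lower number from compound 2 to compound 3 (0.28 log units; within the scatter), so the two cannot be ranked against each other.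

Compound 4, `COc1cc2c(Oc3ccc(NC(=O)c4cc(-c5ccc(Cl)c(Cl)c5)nc5ccccc45)cc3F)ccnc2cc1OCCCN1CCCCC1`, is the next step: chloro in place of hydrogen on an aromatic carbon. Going by the values given here, no measured step adds a second halogen to a ring that already carries one. The nearest comparison is the exchange of one halogenated ring for another, a 1.9-fold lower number from compound 2 to compound 3 (0.28 log units; within the scatter), which stayed within the scatter; the large steps, a 14-fold lower number from compound 1 to compound 2 (1.14 log units; beyond the scatter) and a 26-fold lower number from compound 1 to compound 3 (1.42 log units; beyond the scatter), involve the loss of a methoxy group and so say little here. For compound 4 the expected step is therefore small, a 1.1-fold lower number from compound 3 to compound 4 (0.04 log units; within the scatter), and compound 4 is estimated at 10 nM, somewhere between 4 nM and 30 nM.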

Compound 4, half-maximal inhibitory concentration: 820 nM
Beside the measured number, compound 4's estimate is 82-fold (1.91 log units) below it; measured number above the stated range.
By their numbers in this assay, from the lowest: compounds 3 and 2 (each within the scatter of the next); then compound 1; then compound 4.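

On the 3-chlorophenyl ring, one chloro placed ortho to the existing chloro group is far from a neutral change, despite adding a single heavy atom (a 75-fold higher number from compound 3 to compound 4 (1.87 log units; beyond the scatter)). The 3,4-dichlorophenyl ring also gives a much higher number than the 4-fluorophenyl ring (a 39-fold higher number from compound 2 to compound 4 (1.59 log units; beyond the scatter)) and a modestly higher one than the 4-methoxyphenyl ring (a 2.8-fold higher number from compound 1 to compound 4 (0.45 log units; beyond the scatter)), so halogenated rings here span both ends of the range. No available measurement explains this jump. Still open, from the compounds shown here alone, is whether the loss follows from chloro specifically or would also appear with another group on that carbon, such as a methyl or an amine.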